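A few compounds are considered here, and "the series" means these few. Any claim that something is new, unique, unknown or untested is made for them only; others in the source may bear on it.

Measured so far in a functional assay on PC-3 cells (Homo sapiens) for inhibition; on this read-out lower numbers stand for stronger inhibition and higher numbers for weaker inhibition:
compound 1, `COc1cc2nc(N3CCN(S(=O)(=O)c4ccc([N+](=O)[O-])cc4)CC3)nc(N)c2cc1OC`, 36000 nM
compound 2, `COc1cc2nc(N3CCN(S(=O)(=O)c4ccc(C(C)(C)C)cc4)CC3)nc(N)c2cc1OC`, 4100 nM

Compound 2 stands at the lowest of the two numbers, and compound 1 sits above it by the step of an 8.8-fold lower number from compound 1 to compound 2 (0.94 log units; beyond the scatter), which lies beyond the scatter. Compound 3, `COc1cc2nc(N3CCN(S(=O)(=O)c4cc(C(=O)O)c(Cl)cc4Cl)CC3)nc(N)c2cc1OC`, has not yet been measured. It differs from compound 2 in a single place: 5-carboxy-2,4-dichlorophenyl in place of 4-(tert-butyl)phenyl on a sulfonyl sulfur. Among the compounds with values here, only one measured step bears on this change, an 8.8-fold lower number from compound 1 to compound 2 (0.94 log units; beyond the scatter), and it does so loosely: it also swapped the substituent of the aryl group carried on the sulfonyl sulfur and showed that such a swap can move the number by a modest amount. Within the data shown here, no measured pair contains a carboxy or a chloro group, so the direction for compound 3 is uncertain. Compound 3 is estimated at 15000 nM, within 4000 nM to 60000 nM, which means an expected step of a 3.7-fold higher number from compound 2 to compound 3 (0.56 log units; beyond the scatter) towards weaker inhibition.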

Compound 3, half-maximal inhibitory concentration: 52000 nM
Compound 3: middle estimate off by 3.5-fold (0.54 log units), on the low side, and the stated range covers the measured number.
By their numbers in this assay, from the lowest: compound 2; then compounds 1 and 3 (each within the scatter of the next).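

In this assay replacing 4-(tert-butyl)phenyl on the sulfonyl sulfur with 5-carboxy-2,4-dichlorophenyl gives a 13-fold higher number from compound 2 to compound 3 (1.10 log units; beyond the scatter) and so shows that this position can move the number further than the earlier pair alone showed. Against 4-nitrophenyl the same group gives a 1.4-fold higher number from compound 1 to compound 3 (0.16 log units; within the scatter) with that step inside the scatter, so these two aryl groups cannot be told apart here, and among the three compounds only compound 2 stands apart from the others.

On these data alone, compound 3 brings in the carboxy group and both chloro groups together, so it remains open which of them carries the step, and whether a methyl ester or a primary amide in place of the carboxylic acid would give a different number. No measurement at hand accounts for why these aryl groups give the numbers they do.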